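A few compounds are considered here, and "the series" means these few. Any claim that something is new, unique, unknown or untested is made for them only; others in the source may bear on it.

Measured compounds:
Compound 1, `O=C(Nc1ccccc1)Nc1cccc(-c2nc(-c3ccc(NC(=O)c4cccnc4)cc3Cl)no2)c1`, in a functional assay on MDA-MB-231 cells (Homo sapiens) for antiproliferative activity, read by MTT assay, with a stated time of 72 h (a lower number here means a stronger inhibitor, a higher number a weaker inhibitor), gives > 10000 nM, which is a limit of the assay rather than a number.
Compound 2, `O=C(Nc1ccc(Cl)cc1)Nc1cccc(-c2nc(-c3ccc(NC(=O)c4cccnc4)cc3Cl)no2)c1`, in this assay gives > 10000 nM, also a limit.
Compound 3, `CC(=O)Nc1ccc(NC(=O)Nc2cccc(-c3nc(-c4ccc(NC(=O)c5cccnc5)cc4Cl)no3)c2)cc1`, in this assay gives > 10000 nM, again a limit.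

All three values sit at the limit of > 10000 nM in this assay, at which 3 of the 3 values shown sit, so none of the steps among them can be read: a step that the two limits leave unreadable from compound 1 to compound 2, a step that the two limits leave unreadable from compound 1 to compound 3, a step that the two limits leave unreadable from compound 2 to compound 3. Compound 4, `CC(=O)Nc1ccc(NC(=O)Nc2cccc(-c3nc(-c4ccc(NC(=O)c5cccnc5)cc4Cl)no3)c2)cc1Cl`, has not yet been measured. It differs from compound 3 by chloro in place of hydrogen on an aromatic carbon. The same change has been made once before, from compound 1 to compound 2, where it reads (chloro in place of hydrogen on an aromatic carbon). The two cores differ as described by acetamido in place of hydrogen on an aromatic carbon. The surroundings of the entering chloro are not the same in the two pairs: in compound 2 it is para to a large group, in compound 4 it is ortho to an acetamido group and meta to a large group, so this is the same kind of change, not the same one. The earlier step that the two limits leave unreadable from compound 1 to compound 2 gives no readable size. With three limits and nothing else to build on, compound 4 is expected to stay near that limit too, at an expected step that the limit leaves unreadable from compound 3 to compound 4. The estimate for compound 4 in this assay is 15000 nM, expected between 4000 nM and 60000 nM.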

Compound 4, half-maximal inhibitory concentration: > 10000 nM
Compound 4 gave a limit, no number (the forecaster's own chance of this, stated with the estimate: 80%); the middle value does not contradict the limit.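

Compound 4 also gives only a limit, so the steps linking it to compound 1, compound 2 and compound 3 cannot be read: the limit of > 10000 nM in this assay, at which 4 of the 4 values shown sit.

The compounds shown leave open whether chloro or acetamido changes the activity in this assay at all, and how weak each of these four compounds really is.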